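A few compounds are considered here, and "the series" means these few. Any claim that something is new, unique, unknown or untested is made for them only; others in the source may bear on it.

Compound 1, `CCCCCCCC(=O)OCC(C)(C)CC1=C(O)C(=O)c2ccccc2C1=O`, is the starting point of this account. In an ADME assay on Vero cells (Chlorocebus sabaeus) for cytotoxicity, read by MTT assay (on this read-out lower numbers stand for stronger inhibition and higher numbers for weaker inhibition), compound 1 reaches only the limit of the assay, > 258000 nM. Among the measured compounds shown here, its single measured partner is compound 2, `CCCCCCC(C)C(=O)OCC(C)(C)CC1=C(O)C(=O)c2ccccc2C1=O`, which in this assay gives 450 nM. For the measured compounds named here, the one recorded step, an at least 570-fold lower number from compound 1 to compound 2 (2.75 log units; beyond the scatter), is thus large, though it is bounded on one side by the limit of > 258000 nM in this assay, at which 1 of the 2 values shown sits.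

Compound 3, `CCCCCCCCCCCCCCCC(=O)OCC(C)(C)CC1=C(O)C(=O)c2ccccc2C1=O`, differs from compound 1 in a different manner: octyl in place of hydrogen on a saturated chain carbon, seven bonds along the chain from a carbonyl carbon. Going by the values given here, no measured step follows a change of this kind; the step from compound 1 to compound 2 concerns a methyl on another carbon and gives no guide to a longer chain. What is known is that compound 1 itself stands at a limit. Compound 3 therefore begins from a point where only a limit has been recorded.

Compound 3 is expected to move by an at least 2.5-fold lower number from compound 1 to compound 3 (0.41 log units; beyond the scatter), with no strong reason for a shift beyond the scatter. The estimate for compound 3 in this assay is 100000 nM, within a range from 10000 nM to 300000 nM.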

Compound 3, half-maximal inhibitory concentration: 4410 nM
Beside the measured number, compound 3's estimate is 23-fold (1.36 log units) above it, outside the stated range (below it).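

In this assay, octyl in place of hydrogen, seven bonds along the chain from a carbonyl carbon, gives an at least 58-fold lower number from compound 1 to compound 3 (1.76 log units; beyond the scatter), a large step. Among the compounds shown here, until now, the only change seen to lower the number from compound 1 was a methyl on the saturated chain carbon bound to the carbonyl carbon, so this result shows that a change on a different carbon of the chain can also give a step beyond the scatter. The step has only one bound, because compound 1 stands at a limit and not at a number: the limit of > 258000 nM in this assay, at which 1 of the 3 values shown sits.

The compounds shown leave open how the step depends on the length of the group at this place, for a butyl group, for example, or for a chain longer than octyl such as dodecyl. They also leave open whether an amine or a carboxylic acid at this same place would give a lower number in this assay as octyl does.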